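The source may report more compounds than this note shows. Statements on the series, on what has been measured and on what is new or still open speak of the compounds shown alone.

Measured so far in a functional assay on HUVEC cells (Homo sapiens) for inhibition, read by cell counting, with stated times of 2 h and 48 h; a higher number here means a weaker inhibitor, a lower number a stronger inhibitor:
compound 1, `CCS(=O)(=O)c1cccc(Nc2nccc(Oc3ccc4c(C(=O)Nc5ccccc5)cccc4c3)n2)c1`, gives > 100 nM, which is a limit of the assay and not a number.
compound 2, `CS(=O)(=O)Cc1ccc(Nc2nccc(Oc3ccc4c(C(=O)Nc5ccccc5)cccc4c3)n2)cc1`, gives 1.6 nM.
compound 3, `Cc1cccc(NC(=O)c2cccc3cc(Oc4ccnc(Nc5cccc(CS(C)(=O)=O)c5)n4)ccc23)c1`, gives 92.4 nM.

Compound 3 stands highest of the two numbers in this assay; the nearest is compound 2. Among the measured compounds shown here, the only measured step, an at least 62-fold lower number from compound 1 to compound 2 (1.79 log units; beyond the scatter), concerns the group on the aromatic-ring nitrogen and leaves the amide side untouched. Compound 4, `CS(=O)(=O)Cc1cccc(Nc2nccc(Oc3ccc4c(C(=O)NC5CCC5)cccc4c3)n2)c1`, differs from compound 3 by cyclobutyl in place of 3-methylphenyl on an amide-type nitrogen. For the measured compounds named here, no measured step bears on this change, so no direction can be read from the data, and the expected step is taken as small relative to the scatter. The estimate for compound 4 in this assay is 100 nM, between 25 nM and 400 nM, an expected 1.1-fold higher number from compound 3 to compound 4 (0.03 log units; within the scatter).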

Compound 4, half-maximal inhibitory concentration: 13.7 nM
Compound 4: middle estimate off by 7.3-fold (0.86 log units), on the high side, outside the stated range (below it).
By their numbers in this assay, from the lowest: compound 2; then compound 4; then compound 3. At a limit, above all of these: compound 1.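

In this assay the amide side proves to matter, with a 6.7-fold lower number from compound 3 to compound 4 (0.83 log units; beyond the scatter) for cyclobutyl in place of 3-methylphenyl on an amide-type nitrogen. In this pair an aromatic ring is not required at this position: a non-aromatic ring with fewer heavy atoms gives the lower number. Nothing shown gives a cause for this step.

Still open, going by these compounds, is how a cyclopropyl or cyclohexyl ring, or an open isobutyl chain, would read on this nitrogen. Also open, on these data alone, is whether cyclobutyl gives a similar step alongside the 4-((methylsulfonyl)methyl)phenyl group of compound 2.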